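A few compounds are considered here, and "the series" means these few. Any claim that something is new, unique, unknown or untested is made for them only; others in the source may bear on it.

The compounds measured so far in a functional assay on the whole organism (strain Kunming) for inhibition, with Mus musculus as the target, with a stated time of 1 h, at a dose of 40 mg/kg by the oral route; a lower number here means less inhibition, a higher number more inhibition at the dose given (going by the name of the read-out):

Compound 1 `Cc1ccc(S(=O)(=O)N2CCN(c3ccc(C(=O)/C=C/c4ccccc4)cc3)CC2)cc1` gives 30.8%.
Compound 2 `O=C(/C=C/c1ccccc1)c1ccc(N2CCN(S(=O)(=O)c3ccc(OC(F)(F)F)cc3)CC2)cc1` gives 47.4%.
Compound 3 `CCCCc1ccc(S(=O)(=O)N2CCN(c3ccc(C(=O)/C=C/c4ccccc4)cc3)CC2)cc1` gives 24%.

Compound 3 has the lowest of the three numbers, but its gap to compound 1 is within the scatter, so the two cannot be ranked against each other; only compound 2 stands clearly apart, as the step of a number 23.4 percentage points lower from compound 2 to compound 3 (beyond the scatter) shows.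

Compound 4 `COc1ccc(S(=O)(=O)N2CCN(c3ccc(C(=O)/C=C/c4ccccc4)cc3)CC2)cc1OC` differs from compound 3 in one place: 3,4-dimethoxyphenyl in place of 4-butylphenyl on a sulfonyl sulfur. The two steps that bear on this are those that also swap the group on the phenyl bound to the sulfonyl sulfur. The step of a number 16.6 percentage points higher from compound 1 to compound 2 (beyond the scatter) raised the inhibition, and the step of a number 23.4 percentage points lower from compound 2 to compound 3 (beyond the scatter) lowered it again, while the step of a number 6.8 percentage points lower from compound 1 to compound 3 (within the scatter) stayed within the scatter. So far, the group that brings oxygen onto that ring gave the higher number, and the two groups of carbon alone stayed below it. Among the compounds with values here, since the entering 3,4-dimethoxyphenyl also brings oxygen, a rise from compound 3 is expected, of modest size, though only two informative steps support this.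

The expected step is a number 12 percentage points higher from compound 3 to compound 4 (beyond the scatter). Compound 4 is therefore estimated at 36%, with a range from 18% to 55%.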

Compound 4, a percentage reported as inhibition, in the whole organism at one dose (the size of the read-out at that dose, not a potency): 55.5%
The estimate for compound 4 lay 19.5 percentage points below the measured number; the whole stated range lies below it.
By their numbers in this assay, from the lowest: compounds 3 and 1 (each within the scatter of the next); then compounds 2 and 4 (each within the scatter of the next).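

In this assay, within the data shown here, changing only the group on the sulfonyl sulfur can move the number much further than the earlier compounds showed: the switch to 3,4-dimethoxyphenyl gives a number 31.5 percentage points higher from compound 3 to compound 4 (beyond the scatter) and is the largest step yet seen at this position. The same group in place of 4-methylphenyl also clears the scatter, with a number 24.7 percentage points higher from compound 1 to compound 4 (beyond the scatter) showing that the rise does not depend on the butyl compound alone as a starting point. Against the other oxygen-bearing group, however, there is a number 8.1 percentage points higher from compound 2 to compound 4 (within the scatter) as the result, so 3,4-dimethoxyphenyl and 4-(trifluoromethoxy)phenyl cannot be ranked, and among these four compounds both stay clear of the two with carbon-only groups on that ring, with no compound going against this split. No measurement shown here explains the split.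

A ring carrying a single methoxy group would help show whether one oxygen-bearing group is enough or whether the pair in compound 4 matters. Going by these compounds, it also remains open whether an amine or a carboxylic acid on this ring would fall with the higher pair or the lower pair.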